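A few compounds are considered here, and "the series" means these few. Any claim that something is new, unique, unknown or untested is made for them only; others in the source may bear on it.

Of the compounds shown here, three built on one shared core have been tested in a functional assay on MDA-MB-231 cells (Homo sapiens) for antiproliferative activity, read by sulforhodamine B assay; a higher number here means a weaker inhibitor of growth, a lower number a stronger inhibitor of growth. Compound 1 `O=C(Nc1nc2ccc([N+](=O)[O-])cc2s1)c1ccc(C(F)(F)F)cc1` gives 1.89 ug/mL in this assay. Compound 3 `COc1cccc2sc(NC(=O)c3ccc([N+](=O)[O-])cc3)nc12` stops at a limit of this assay, > 10 ug/mL, so no number is known for it. Compound 2 `COc1ccc(C(=O)Nc2nc3cc(OC)ccc3s2)cc1` likewise stands at a limit, > 10 ug/mL, which is the limit of > 10 ug/mL in this assay, at which 2 of the 3 values shown sit. Compound 2 therefore holds no number of its own, only the mark of the assay ceiling, and it shares that mark with compound 3, while compound 1 is the only one of the three with a measured figure.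

Compound 4 `COc1ccc2sc(NC(=O)c3ccc(C#N)cc3)nc2c1` has not been measured. It differs from compound 2 by cyano in place of methoxy on an aromatic carbon. Going by the values given here, no two measured compounds differ in one place, so there is no measured step to set the size of this change against. The step that the limit leaves unreadable from compound 2 to compound 4 is expected to be none beyond the scatter. Compound 4 is estimated at 12 ug/mL, with a range from 4 ug/mL to 40 ug/mL, and most likely only another limit will be reported.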

Compound 4, concentration for 50% growth inhibition: > 10 ug/mL
Compound 4 ended at the assay's limit; the forecaster's own chance of this, stated with the estimate: 65%; the middle value does not contradict the limit.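

No step can be read from compound 2 to compound 4, because both stand at a limit and not at a number: the limit of > 10 ug/mL in this assay, at which 3 of the 4 values shown sit. The compounds shown leave open whether cyano in place of methoxy on an aromatic carbon changes growth inhibition at all.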